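Methoxy removal on the styryl phenyl of compound 3

A few compounds are considered here, and "the series" means these few. Any claim that something is new, unique, unknown or untested is made for them only; others in the source may bear on it.

Measured compounds in a functional assay on A549 cells (Homo sapiens) for antiproliferative activity, read by MTT assay, with a stated time of 24 h; on this read-out higher numbers stand for weaker inhibition and lower numbers for stronger inhibition:
- compound 1, `COc1cc(-c2cc(/C=C/C(=O)c3ccc(C)c(C)c3)nc3cc(-c4ccccc4)nn23)cc(OC)c1OC`: 10600 nM
- compound 2, `COc1ccc(-c2cc(C(=O)/C=C/c3ccccc3)nc3cc(-c4ccccc4)nn23)cc1OC`: 18600 nM
- compound 3, `COc1ccc(/C=C/C(=O)c2cc(-c3cc(OC)c(OC)c(OC)c3)n3nc(-c4ccccc4)cc3n2)cc1`: 21200 nM

Compound 3 gives the highest of the three numbers, but every gap to the others is within the scatter: compound 2 is nearest, and compound 1, the furthest, lies a step of a 2.0-fold higher number from compound 1 to compound 3 (0.30 log units; within the scatter) away. For the measured compounds named here, on these numbers no compound can be set apart from the others.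

Compound 4, `COc1cc(-c2cc(C(=O)/C=C/c3ccccc3)nc3cc(-c4ccccc4)nn23)cc(OC)c1OC`, has not been measured. It differs from compound 3 by hydrogen in place of methoxy on an aromatic carbon; cut one bond further out, the change reads 4-methoxyphenyl to phenyl.

Going by the values given here, no measured step covers this change. Among the compounds with values here, the only step recorded, a 2.0-fold higher number from compound 1 to compound 3 (0.30 log units; within the scatter), alters a different part of the molecule and is itself within the scatter. Compound 2 carries the same (2-phenylethenyl)carbonyl group that compound 4 will carry, and compound 2 gives 18600 nM, but it also differs from compound 4 elsewhere, so it cannot serve as a direct comparison.

With nothing pointing either way, no step beyond the scatter is expected. The estimate means a step of a 1.1-fold lower number from compound 3 to compound 4 (0.05 log units; within the scatter), expected to stay within the scatter. For compound 4 the expected value is 19000 nM, with a range from 8000 nM to 45000 nM.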

Compound 4, half-maximal inhibitory concentration: 18000 nM
Estimate against measurement, compound 4: 1.1-fold (0.02 log units) above; measured number inside the range.
By their numbers in this assay, from the lowest: compounds 1, 4, 2 and 3 (each within the scatter of the next).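

Taking the methoxy off the 4-methoxyphenyl group gives the first step read at this position, a 1.2-fold lower number from compound 3 to compound 4 (0.07 log units; within the scatter) in this assay, so 4-methoxyphenyl and phenyl cannot be told apart here. The two other new steps are also within the scatter: a 1.0-fold lower number from compound 2 to compound 4 (0.01 log units; within the scatter) for a methoxy change on the other methoxy-bearing phenyl ring, and a 1.7-fold higher number from compound 1 to compound 4 (0.23 log units; within the scatter) for the exchange of the whole 2-((3,4-dimethylphenyl)carbonyl)ethenyl group for (2-phenylethenyl)carbonyl. No measurement is available that could explain why any of these changes leaves the number within the scatter.

The compounds shown carry only hydrogen or methoxy at this place on the ring, so it remains open what a dimethylamino group, a carboxylic acid or a longer alkoxy chain would do there. With every step among these compounds within the scatter, it also remains open which part of the molecule, if any, can move the number beyond it.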